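The source may hold more compounds than are shown below. What is called first, only, known or untested is meant among the compounds shown, and "the series" means these compounds.

Measured compounds and their values in a functional assay on QGY-7703 cells (Homo sapiens) for cytotoxicity, read by MTT assay, with a stated time of 24 h; on this read-out lower numbers stand for stronger inhibition and higher numbers for weaker inhibition:

- compound 1, `CN1C/C(=C\c2cccnc2)C(=O)/C(=C/c2ccccc2F)C1`: 4470 nM
- compound 2, `CN1C/C(=C\c2ccc(C(F)(F)F)cc2)C(=O)/C(=C/c2cccnc2)C1`: 1660 nM
- compound 3, `CN1C/C(=C\c2ccncc2)C(=O)/C(=C/c2ccccc2F)C1`: 4900 nM

Compound 3 differs from compound 1 by one change, (pyridin-4-yl in place of pyridin-3-yl on a double-bonded chain carbon bound to a double-bonded ring carbon). The step this change made in this assay was a 1.1-fold higher number from compound 1 to compound 3 (0.04 log units; within the scatter), so the two compounds cannot be told apart on this read-out. Compound 2 gives the lowest of the three numbers, and its separation from compound 1 and from compound 3 lies beyond the scatter in both cases. How the core of compound 2 differs from the core of compound 1 is not broken down here; the two differ in more than one place, and their values are all that can be compared.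

Compound 4, `CN1C/C(=C\c2ccncc2)C(=O)/C(=C/c2ccc(C(F)(F)F)cc2)C1`, has not yet been measured in this assay. It differs from compound 2 by pyridin-4-yl in place of pyridin-3-yl on a double-bonded chain carbon bound to a double-bonded ring carbon. This is the same change, at the same place, as the one from compound 1 to compound 3, and it occurs twice among the compounds shown. Among the measured compounds shown here, for compound 4 the step from compound 2 is expected to be about a 1.1-fold higher number from compound 2 to compound 4 (0.04 log units; within the scatter), because the only earlier instance of this change, a 1.1-fold higher number from compound 1 to compound 3 (0.04 log units; within the scatter), lay within the scatter. Compound 4 is therefore estimated at 1800 nM in this assay, with a likely range from 900 nM to 3600 nM. The estimate rests on two compounds only; a further pair would be needed to see whether the change is neutral elsewhere in the series.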

Compound 4, half-maximal inhibitory concentration: 10400 nM
Beside the measured number, compound 4's estimate is 5.8-fold (0.76 log units) below it, and the stated range ends below it.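

In this assay, pyridin-4-yl in place of pyridin-3-yl on a double-bonded chain carbon bound to a double-bonded ring carbon gives a 6.3-fold higher number from compound 2 to compound 4 (0.80 log units; beyond the scatter), so on the core of compound 2 this change is not neutral. The change therefore does not carry over from one core to the other with the same size, and a step read on the core of compound 1 is a poor guide to the step on the core of compound 2: the same change on two cores in this assay, a 1.1-fold higher number (0.04 log units; within the scatter) from compound 1 to compound 3 and a 6.3-fold higher number (0.80 log units; beyond the scatter) from compound 2 to compound 4, 5.7-fold (0.76 log units) apart, beyond the scatter of two such steps. Among the compounds shown here, with only one pair on each core, this shows that the size of the step differs between these two cores, but it does not show which difference between the cores goes with the larger step, nor what the change would do on a third core.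

Still open, on these data alone, is whether the step on any further core would resemble the near-absent one or the large one, and whether pyridin-2-yl or a plain phenyl in the same place would follow either pair. Also open, as far as these compounds go, is how the change would behave with a carboxylic acid or an amine on the other aromatic group in place of trifluoromethyl or fluorine.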